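Methoxy for ethyl on the five-membered ring: compound 4

The source may report more compounds than this note shows. Statements on the series, on what has been measured and on what is new or still open speak of the compounds shown alone.

Measured in a functional assay on the whole organism (6C3HED cells, Mus musculus) for inhibition, at a dose of 300 mg/kg by the oral route; a lower number here means less inhibition, a higher number more inhibition at the dose given (going by the name of the read-out):

compound 1, `COc1ccc(S(=O)(=O)NC(=O)Nc2ccc(Cl)cc2)s1`: 100%
compound 2, `CCc1ccc(S(=O)(=O)NC(=O)Nc2ccc(Cl)cc2)s1`: 89%
compound 3, `CCc1csc(S(=O)(=O)NC(=O)Nc2ccc(Cl)cc2)c1`: 93%

All three share the sulfonylurea link to the chlorophenyl group and differ only in the five-membered ring on the sulfonyl sulfur and its substituent. Compound 2 and compound 3 have the same atoms joined differently; how the two cores differ is given by a group of 7 heavy atoms (6 carbon, 1 sulfur; one five-membered aromatic ring with 1 hetero atom) in place of a group of 7 heavy atoms (6 carbon, 1 sulfur; one five-membered aromatic ring with 1 hetero atom), on a sulfonyl sulfur, and the step it made was a number 4 percentage points higher from compound 2 to compound 3 (within the scatter). Compound 1 and compound 3 lie close together as well: a number 7 percentage points lower from compound 1 to compound 3 (within the scatter).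

Among the measured compounds shown here, the one step in the set that goes beyond the scatter is the exchange (methoxy in place of ethyl on an aromatic carbon), which gave a number 11 percentage points higher from compound 2 to compound 1 (beyond the scatter). Compound 4, `COc1csc(S(=O)(=O)NC(=O)Nc2ccc(Cl)cc2)c1`, is not yet measured. Its difference from compound 3 is methoxy in place of ethyl on an aromatic carbon, the same kind of change as from compound 2 to compound 1, but not the same: in compound 1 the methoxy stands next to the ring sulfur, whereas in compound 4 it stands two ring bonds from the ring sulfur; in both it is two ring bonds from the ring atom that bears a large group.

The expected step in this assay from compound 3 to compound 4 is a number 4 percentage points higher from compound 3 to compound 4 (within the scatter), smaller than the earlier one because compound 3 already gives 93% and the read-out cannot rise far above it. On this basis compound 4 is estimated at 97%, expected between 88% and 100%.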

Compound 4, a percentage reported as inhibition, in the whole organism at one dose (the size of the read-out at that dose, not a potency): 69%
The estimate for compound 4 lay 28 percentage points above the measured number; measured number below the stated range.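

In this assay the exchange of ethyl for methoxy does not carry over from one core to the other, neither in size nor in direction: the same change on two cores in this assay, a number 11 percentage points higher (beyond the scatter) from compound 2 to compound 1 and a number 24 percentage points lower (beyond the scatter) from compound 3 to compound 4, 35 percentage points apart, beyond the scatter of two such steps With methoxy on both sides, moving it on the ring gave a number 31 percentage points lower from compound 1 to compound 4 (beyond the scatter), while the ethyl pair shows only a number 4 percentage points higher from compound 2 to compound 3 (within the scatter), so in these four compounds the place of the group counts for methoxy and not visibly for ethyl. Compound 4 also stands apart from the remaining ethyl compound, with a number 20 percentage points lower from compound 2 to compound 4 (beyond the scatter), a step that changes group and place together and so cannot be given to either alone; with a number 24 percentage points lower from compound 3 to compound 4 (beyond the scatter) as the direct exchange, the result shows that this change cannot be transferred between these two cores, but it rests on one pair per core at a single dose and does not show what lies behind the difference.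

Going by these compounds, whether the fall belongs to methoxy in particular or to any group other than ethyl at this ring carbon stays open, and an ethoxy group, a dimethylamino group or a longer chain such as butyl there would begin to separate these cases. Also open, on these data alone, is whether the gap between the two cores holds at lower oral doses, where the numbers would sit further from the top of the scale.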